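This account rests on a few compounds, and the source may have more. Where it says the series, first, only, none or still open, it means among the compounds named here.

Of the compounds shown here, three have been measured so far: compound 1 `COc1cc(N2CCN(C(=O)Cn3cnc4ccc(C(F)(F)F)cc43)CC2)ccc1-c1cnc(C)o1`, compound 2 `COc1cc(N2CCN(C(=O)N[C@@H](C)c3cccc4ccccc34)CC2)ccc1-n1cnc(C)c1` and compound 3 `COc1cc(N2CCN(C(=O)Cn3ccc4ccccc43)CC2)ccc1-c1cnc(C)o1`, all in an ADME assay on microsomes from liver (Rattus norvegicus) for metabolic stability, read by LC-MS; on this read-out higher numbers stand for fast clearance and lower numbers for slow clearance. Compound 1 gives 23 mL.min-1.g-1. Compound 3 gives 140 mL.min-1.g-1. Compound 2 gives 150 mL.min-1.g-1, the highest of the three numbers shown; its gap to compound 3 is within the scatter, while its gap to compound 1 lies beyond it. Compound 4 `COc1cc(N2CCN(C(=O)N[C@@H](C)c3cccc4ccccc34)CC2)ccc1-c1cnc(C)o1` has not yet been measured in this assay. It differs from compound 2 in one place: 2-methyl-1,3-oxazol-5-yl in place of 4-methyl-1H-imidazol-1-yl on an aromatic carbon. Among the measured compounds shown here, no pair of measured compounds isolates this change. Compound 3 and compound 1 both carry the 2-methyl-1,3-oxazol-5-yl group, yet their numbers differ widely, so that group alone does not fix the result. The step from compound 2 to compound 4 is expected to be small, a 1.3-fold lower number from compound 2 to compound 4 (0.10 log units; within the scatter), with no direction beyond the scatter. Compound 4 is estimated to give 120 mL.min-1.g-1 in this assay, with a likely range from 50 mL.min-1.g-1 to 260 mL.min-1.g-1.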

Compound 4, intrinsic clearance in microsomes: 130 mL.min-1.g-1
Estimate against measurement, compound 4: 1.1-fold (0.03 log units) below, and the stated range covers the measured number.
By their numbers in this assay, from the lowest: compound 1; then compounds 4, 3 and 2 (each within the scatter of the next).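

In this assay, among the compounds shown here, exchanging 4-methyl-1H-imidazol-1-yl for 2-methyl-1,3-oxazol-5-yl gives the first reading of this change with the rest of the molecule held fixed: a 1.2-fold lower number from compound 2 to compound 4 (0.06 log units; within the scatter). Both groups are five-membered aromatic rings with 2 hetero atoms, and on this aromatic carbon, ortho to a methoxy group and para to a large group, one can stand in for the other with no clear shift in clearance in this pair. Nothing available offers an explanation for this result.

Going by these compounds, whether the change stays this small when the rest of the molecule differs remains open. So does how this assay would read with a group of another kind at this position, such as a nitrile or a carboxylic acid.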